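Swapping the acid-bearing linker on a shared core

This account rests on a few compounds, and the source may have more. Where it says the series, first, only, none or still open, it means among the compounds named here.

Measured so far:
compound 2 `O=C(O)CSc1ccc(NCc2cccc(Oc3ccccc3)c2)cc1` gives 324 nM in a functional assay on CHO cells for agonist activity at Free fatty acid receptor 1 (Homo sapiens); a higher number here means that more compound is needed for the effect, a lower number that less compound is needed
compound 1 `O=C(O)CCCc1ccc(NCc2cccc(Oc3ccccc3)c2)cc1` gives 1120 nM in this assay

Compound 2 has the lowest of the two numbers. Compound 3 `CC(CC(=O)O)c1ccc(NCc2cccc(Oc3ccccc3)c2)cc1` is not yet measured; it differs from compound 2 in one place: 1-(carboxymethyl)ethyl in place of (carboxymethyl)sulfanyl on an aromatic carbon. Among the compounds with values here, the only measured step, a 3.5-fold lower number from compound 1 to compound 2 (0.54 log units; beyond the scatter), also changes this acid-bearing group and stays modest, so the new linker is expected to move the number little. For compound 3 a value near 350 nM is estimated, between 120 nM and 1000 nM, meaning a 1.1-fold higher number from compound 2 to compound 3 (0.03 log units; within the scatter).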

Compound 3, half-maximal effective concentration: 126 nM
Beside the measured number, compound 3's estimate is 2.8-fold (0.44 log units) above it; low and high end bracket the measured number.
By their numbers in this assay, from the lowest: compound 3; then compound 2; then compound 1.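

Sulfur is not required at this position: the all-carbon 1-(carboxymethyl)ethyl group gives a 2.6-fold lower number from compound 2 to compound 3 (0.41 log units; beyond the scatter) and now holds the lowest number of the three. Yet 3-carboxypropyl also contains no sulfur, and 1-(carboxymethyl)ethyl in its place gives an 8.9-fold lower number from compound 1 to compound 3 (0.95 log units; beyond the scatter) with the sulfur-linked compound 2 falling between them, so compound 1 goes against any simple rule that all-carbon linkers give lower numbers. As far as these compounds go, it remains open whether a carboxymethoxy group, or a tetrazole in place of the carboxylic acid, would lower the number further. No measurement shown here explains these differences.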